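Cytotoxicity at the 6-substituent: pyrrolidine to cyclopentylamine

This account rests on a few compounds, and the source may have more. Where it says the series, first, only, none or still open, it means among the compounds named here.

- Compound 1 `CC(C)CSc1nc(N)nc2c1ncn2/C=C1/CC1(CO)CO`: 60000 nM
- Compound 2 `Nc1nc(N2CCCC2)c2ncn(/C=C3/CC3(CO)CO)c2n1`: > 20000 nM

Both compounds were tested in an ADME assay on CCRF-HSB-2 cells (Homo sapiens) for cytotoxicity, with a stated time of 7 days; on this read-out lower numbers stand for higher toxicity in this test and higher numbers for lower toxicity in this test. Compound 2 gives > 20000 nM, and this value is a limit, not a number. The record for it is short: the limit of > 20000 nM in this assay, at which 1 of the 2 values shown sits.

The next compound, compound 3 `Nc1nc(NC2CCCC2)c2ncn(/C=C3/CC3(CO)CO)c2n1`, differs from compound 2 in a single place: cyclopentylamino in place of pyrrolidin-1-yl on an aromatic carbon. Cyclopentylamino takes the place of pyrrolidin-1-yl on an aromatic carbon.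

Among the measured compounds shown here, only one measured step bears on this change, and it concerns the same place on the core: a step that the limit leaves unreadable from compound 1 to compound 2. It offers no size to carry over, so no particular direction can be expected in this assay. For the measured compounds named here, the one true number remains that of compound 1, at 60000 nM, and a value of similar order is expected for compound 3.

The estimated step is a step that the limit leaves unreadable from compound 2 to compound 3. For compound 3 the expected value is 40000 nM, with an estimated range from 12000 nM to 100000 nM. The assay may again report only a limit.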

Compound 3, half-maximal cytotoxic concentration: > 20000 nM
Compound 3 gave a limit, no number; the forecaster's own chance of this, stated with the estimate: 45%; the middle value lies beyond the limit too.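

In this assay compound 3 gives > 20000 nM, and this value is a limit, not a number. No step among compound 1, compound 2 and compound 3 can be read from this result: the limit of > 20000 nM in this assay, at which 2 of the 3 values shown sit.

The compounds shown leave open how cyclopentylamino, pyrrolidin-1-yl and isobutylsulfanyl truly rank against one another in this assay.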